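Isopropylamino for Dimethylamino at the Limit of Weak Inhibition

The source may report more compounds than this note shows. Statements on the series, on what has been measured and on what is new or still open speak of the compounds shown alone.

Of the compounds shown here, three have been measured in a functional assay on L02 cells (Homo sapiens) for inhibition, read by Griess assay, with stated times of 1 h and 24 h; a higher number here means a weaker inhibitor, a lower number a stronger inhibitor. Compound 1 `CCCc1nn(C)c2c(NC3CC3)nc(/C=C/c3nc(C)c(C)nc3C)nc12` gives 706000 nM in this assay. Compound 2 `CNc1nc(/C=C/c2ccco2)nc2ccsc12` gives 811000 nM in this assay. Compound 3 `COc1cc(/C=C/c2nc(N(C)C)c3sccc3n2)cc(OC)c1OC` reaches only a limit of this assay, > 1000000 nM, and so has no number of its own. It sits at the limit of > 1000000 nM in this assay, at which 1 of the 3 values shown sits. On the numbers shown, then, compound 3 stands apart from compounds 1 and 2 only in that its value is a limit rather than a measurement; all three are weak inhibitors.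

Compound 4 `COc1cc(/C=C/c2nc(NC(C)C)c3sccc3n2)cc(OC)c1OC` differs from compound 3 in one place: isopropylamino in place of dimethylamino on an aromatic carbon. Among the measured compounds shown here, no step between measured compounds is available to judge the size of such a change, and the structural change is small. The step from compound 3 to compound 4 is therefore expected to be a number no higher from compound 3 to compound 4 (the limit leaves the size open), that is, none beyond the scatter, with compound 4 likely also reported as a limit. Compound 4 is estimated at 1000000 nM in this assay, with a range from 400000 nM to 3000000 nM.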

Compound 4, half-maximal inhibitory concentration: > 1000000 nM
Compound 4 ended at the assay's limit; the forecaster's own chance of this, stated with the estimate: 60%; the middle value sits exactly at the limit.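

In this assay compound 3 and compound 4 both stand at a limit, so no step between them can be read: the limit of > 1000000 nM in this assay, at which 2 of the 4 values shown sit.

The compounds shown leave open what size of change, if any, isopropylamino in place of dimethylamino on an aromatic carbon brings to inhibition.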